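The compounds below may be only part of what the source reports. "The series", "measured", "known", "first", "only" and "open" are said of these compounds alone.

Measured compounds in an assay on HEK293 cells for inhibition of N-acylethanolamine-hydrolyzing acid amidase (Homo sapiens), read by fluorescence, with stated times of 10 min and 50 min; a lower number here means a stronger inhibitor, a higher number a weaker inhibitor:
compound 1, `O=C(N[C@H]1CNC1=O)OCc1ccc(C2CCOCC2)cc1`, gives 1370 nM
compound 2, `O=C(N[C@H]1CNC1=O)OCc1ccc(OC2CCCCC2)cc1`, gives 2070 nM
compound 3, `CCCCCCCCOC(=O)N[C@H]1CNC1=O`, gives 37 nM

Compound 3 stands lowest of the three numbers in this assay. Its nearest neighbour is compound 1, already beyond the scatter above it, and compound 2 lies furthest, also beyond the scatter. For the measured compounds named here, the single one-change step among the measured compounds is a 1.5-fold higher number from compound 1 to compound 2 (0.18 log units; within the scatter), a swap on an aromatic carbon that stays within the scatter.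

Compound 4, `O=C(N[C@H]1CNC1=O)OCCCCCC1CCCCC1`, differs from compound 3 by cyclohexyl in place of propyl on a saturated chain carbon, five bonds along the chain from an oxygen next to a carbonyl group. Going by the values given here, no measured step touches the end of a saturated chain, so the step from compound 1 to compound 2 does not bear on this change directly; it only shows that exchanging one six-membered saturated group for another on the aromatic carbon left the number where it was. The values of compound 1 and compound 2 also show that both ring-bearing benzyl carbamates sit far above the open-chain compound 3, but neither keeps the saturated chain of compound 3, so they give no direct reading of its chain end.

Among the compounds with values here, with no precedent for the change, the expected step of a 1.5-fold higher number from compound 3 to compound 4 (0.17 log units; within the scatter) in this assay is small, possibly within the scatter, in either direction. Compound 4 is therefore estimated at 55 nM, with a range from 15 nM to 220 nM.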

Compound 4, half-maximal inhibitory concentration: 49 nM
Compound 4: the middle estimate sits 1.1-fold (0.05 log units) above what was measured; the range from low to high includes it.
By their numbers in this assay, from the lowest: compounds 3 and 4 (each within the scatter of the next); then compounds 1 and 2 (each within the scatter of the next).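

Cyclohexyl in place of propyl on a saturated chain carbon, five bonds along the chain from an oxygen next to a carbonyl group, gives a 1.3-fold higher number from compound 3 to compound 4 (0.12 log units; within the scatter) in this assay. For the compounds shown here, this is the only reading at this position, and it shows that the end of the saturated chain can carry a six-membered non-aromatic ring of carbon only, with 6 heavy atoms in place of 3, while the number stays within the scatter of that of compound 3. Compound 1 and compound 2 differ from compound 4 in more than one place, so this step says nothing about their higher numbers, and no measurement is at hand that bears on the result.

The compounds shown leave open whether a phenyl ring, an amine or a carboxylic acid at this chain end would keep the number close to that of compound 3 at 37 nM. Also open, on these data alone, is whether cyclohexyl on a longer chain or a shorter chain would hold the number in the same range.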